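Swapping Methyl for Cyclopropyl on a Piperazine Nitrogen

The source may report more compounds than this note shows. Statements on the series, on what has been measured and on what is new or still open speak of the compounds shown alone.

Compound 2 `CN1CCN(c2ccn3c(-c4ccc(NC(=O)c5ccc([N+](=O)[O-])o5)cc4)cnc3c2)CC1` carries a 4-methylpiperazin-1-yl group on the shared core. In a functional assay on MGC-803 cells (Homo sapiens) for antiproliferative activity, read by CCK-8 assay, with a stated time of 72 h (on this read-out lower numbers stand for stronger inhibition and higher numbers for weaker inhibition), compound 2 gives 1580 nM. Going by the values given here, of the two compounds measured so far this is the higher number; its only neighbour is compound 1 `CC(=O)N1CC=C(c2ccn3c(-c4ccc(NC(=O)c5ccc([N+](=O)[O-])o5)cc4)cnc3c2)CC1`, which gives 940 nM, and the step of a 1.7-fold higher number from compound 1 to compound 2 (0.23 log units; within the scatter) lies within the scatter, so the two cannot be told apart on these numbers. Compound 3 `O=C(Nc1ccc(-c2cnc3cc(N4CCN(C5CC5)CC4)ccn23)cc1)c1ccc([N+](=O)[O-])o1` has not yet been measured. It differs from compound 2 in one place: cyclopropyl in place of methyl on an amine nitrogen in a ring. Among the compounds with values here, no measured step bears directly on this kind of change; the only step on record, a 1.7-fold higher number from compound 1 to compound 2 (0.23 log units; within the scatter), concerns a different exchange and says nothing about the substituent on the ring nitrogen. With no guide beyond the two numbers, compound 3 is expected to stay close to compound 2, so that a 1.2-fold lower number from compound 2 to compound 3 (0.08 log units; within the scatter) is estimated to fall within the scatter. Compound 3 is therefore estimated at 1300 nM, with a range from 500 nM to 3500 nM in this assay.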

Compound 3, half-maximal inhibitory concentration: 1650 nM
Beside the measured number, compound 3's estimate is 1.3-fold (0.10 log units) below it; the measured number falls inside the stated range.
By their numbers in this assay, from the lowest: compounds 1, 2 and 3 (each within the scatter of the next).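

In this assay, the ring nitrogen three ring bonds from the ring atom that bears a large group takes cyclopropyl in place of methyl with no readable difference, the step being a 1.0-fold higher number from compound 2 to compound 3 (0.02 log units; within the scatter) on this first direct test of that nitrogen's substituent. The swap adds two heavy atoms and a three-membered ring, yet the two compounds cannot be told apart on these numbers. Exchanging the whole group on the aromatic carbon gives a 1.8-fold higher number from compound 1 to compound 3 (0.24 log units; within the scatter), so 4-cyclopropylpiperazin-1-yl cannot be separated from the group it replaces in that step either, and no information is available that could explain any of these numbers.

On these data alone, what stays open is whether any group on this ring nitrogen can move the number beyond the scatter, for instance a plain hydrogen giving a free amine, a longer chain such as butyl, or a chain ending in a carboxylic acid. Also open is whether any group on the aromatic carbon of the shared core matters in this assay, since the three compounds shown all lie within the scatter of the next.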